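Benzyloxy to phenoxy in the series of compound 1

This account rests on a few compounds, and the source may have more. Where it says the series, first, only, none or still open, it means among the compounds named here.

Measured so far in an ADME assay on MT4 cells (Homo sapiens) for cytotoxicity, read by MTT assay, with a stated time of 96 h (a lower number here means that less compound is tolerated, a higher number that more compound is tolerated), for three compounds:
- compound 1 `Cc1ccccc1C1CC(c2ccc(OCc3ccccc3)cc2)=NN1c1ccc(S(N)(=O)=O)cc1` gives >= 100000 nM as a limit
- compound 2 `NS(=O)(=O)c1ccc(N2N=C(c3ccc(OCc4ccccc4)cc3)CC2c2ccc(F)cc2)cc1` gives > 100000 nM as a limit
- compound 3 `NS(=O)(=O)c1ccc(N2N=C(c3ccc(OCc4ccccc4)cc3)CC2c2ccc(Cl)cc2)cc1` gives 70000 nM as a number

Compound 1 has only >= 100000 nM in this assay, which is a limit and not a number. The change to compound 4 `Cc1ccccc1C1CC(c2ccc(Oc3ccccc3)cc2)=NN1c1ccc(S(N)(=O)=O)cc1` is phenyl in place of benzyl on an oxygen on an aromatic ring, counted as phenyl in place of benzyl on an oxygen on an aromatic ring with the rest of the core of compound 1 unchanged.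

Within the data shown here, no measured step makes this change, so the evidence is indirect. The three steps available all lie elsewhere in the molecule. Among the measured compounds shown here, the first is a step that the two limits leave unreadable from compound 1 to compound 2 and gives no size. The other two are an at least 1.4-fold lower number from compound 1 to compound 3 (0.15 log units; that floor lies within the scatter) and an at least 1.4-fold lower number from compound 2 to compound 3 (0.15 log units; that floor lies within the scatter), and neither floor goes beyond the scatter. On these steps, no shift beyond the scatter is expected in this assay and no firm direction can be given. The estimate is an at least 1.1-fold lower number from compound 1 to compound 4 (0.07 log units; that floor lies within the scatter) and the expectation is that it stays within the scatter. A limit rather than a number is also quite possible. For compound 4 the estimated value is 85000 nM with an expected range from 35000 nM to 130000 nM in this read-out.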

Compound 4, half-maximal cytotoxic concentration: 36000 nM
For compound 4 the middle estimate is 2.4-fold (0.37 log units) above the measured one; measured number inside the range.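

In this assay, phenyl in place of benzyl on an oxygen on an aromatic ring gives the first step among the compounds shown that is printed as beyond the scatter: an at least 2.7-fold lower number from compound 1 to compound 4 (0.44 log units; beyond the scatter). The earlier steps, all at the saturated ring carbon or at the aromatic carbon carrying the halogen, either cannot be read or have floors within the scatter, so benzyloxy to phenoxy is the only change shown so far that clearly moves this read-out, towards less compound being tolerated. The step remains a floor and not a size because compound 1 carries a limit and not a number: the limit of >= 100000 nM in this assay, at which 1 of the 4 values shown sits.

Compounds 2 and 3 have no phenoxy partner among the compounds shown, so it remains open whether the same change gives a step of similar direction with 4-fluorophenyl or 4-chlorophenyl in place of 2-methylphenyl. Also open, on these data alone, is how this assay would read with a longer chain such as phenethyl on the same oxygen, or with an amine or a carboxylic acid on the entering phenyl.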